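This account rests on a few compounds, and the source may have more. Where it says the series, first, only, none or still open, it means among the compounds named here.

Compound 1 `Nc1ncccc1-c1nc2cc(C3CCCC3)cnc2n1-c1ccc(CNC(=O)c2ccccc2)cc1`: 110 nM
Compound 2 `Nc1ncccc1-c1nc2cccnc2n1-c1ccc(CNC(=O)C2CCCCC2)cc1`: 250 nM
Compound 3 `NCc1ccc(-n2c(-c3cccnc3)nc3cccnc32)cc1`: 8800 nM

All three were tested in an in vitro assay on Sf9 cells for inhibition of RAC-alpha serine/threonine-protein kinase (Homo sapiens), read by AlphaScreen, with a stated time of 20 min; on this read-out lower numbers stand for stronger inhibition and higher numbers for weaker inhibition. Compound 2 has the second highest of the three numbers: compound 1 lies below it by more than the usual scatter, and compound 3, which lacks both the acyl group on the methylamine and the amino group on the pyridine, lies far above it. Compound 4 `CC(=O)NCc1ccc(-n2c(-c3cccnc3N)nc3cccnc32)cc1` differs from compound 2 by methyl in place of cyclohexyl on a carbonyl carbon. Among the measured compounds shown here, no measured pair shows this exact change. Because compound 3 gives 8800 nM with the acyl group removed entirely, a smaller acyl group is expected to weaken inhibition. The expected step is a 2.8-fold higher number from compound 2 to compound 4 (0.45 log units; beyond the scatter), which stays well short of that gap. Compound 4 is therefore estimated at 700 nM, within 250 nM to 2500 nM.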

Compound 4, half-maximal inhibitory concentration: 810 nM
Beside the measured number, compound 4's estimate is 1.2-fold (0.06 log units) below it; the range from low to high includes it.
By their numbers in this assay, from the lowest: compound 1; then compound 2; then compound 4; then compound 3.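

In this assay, among the compounds shown here, the step from cyclohexyl to methyl on this carbonyl carbon is the first single change measured at this position: a 3.2-fold higher number from compound 2 to compound 4 (0.51 log units; beyond the scatter). The group here therefore affects the number, yet the modest size of the step shows that inhibition does not depend on having the cyclohexyl ring. Nothing available explains the size of this step.

As far as these compounds go, how a butyl chain or an aminomethyl group on this carbonyl carbon would compare remains open. So does whether the same change would give a similar step on the core of compound 1.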